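The source may hold more compounds than are shown below. What is called first, only, known or untested is meant among the compounds shown, and "the series" means these compounds.

Going by the values given here, compound 2 `Cc1nc(N2CCC(C)(O)CC2)nc2ccc(NC(=O)COc3ccc(Cl)cc3)cc12` carries a 4-hydroxy-4-methylpiperidin-1-yl group on the shared core; in an assay on CHO-K1 cells for displacement of a labelled ligand from melanin-concentrating hormone receptor 1 (Homo sapiens), with a stated time of 2 h (on this read-out higher numbers stand for weaker inhibition and lower numbers for stronger inhibition), compound 2 gives 237 nM, the only numerical value in this set. Compound 1 `Cc1nc(N2CCN(S(C)(=O)=O)CC2)nc2ccc(NC(=O)COc3ccc(Cl)cc3)cc12` reaches only the limit of this assay, > 10000 nM. Among the compounds with values here, the single measured step, an at least 42-fold lower number from compound 1 to compound 2 (1.62 log units; beyond the scatter), is large, and its size is a lower bound, as it rests on (the limit of > 10000 nM in this assay, at which 1 of the 2 values shown sits). Compound 3 `Cc1nc(N2CCN(C)CC2)nc2ccc(NC(=O)COc3ccc(Cl)cc3)cc12` differs from compound 2 by 4-methylpiperazin-1-yl in place of 4-hydroxy-4-methylpiperidin-1-yl on an aromatic carbon. Within the data shown here, the measured step runs from 4-(methylsulfonyl)piperazin-1-yl to 4-hydroxy-4-methylpiperidin-1-yl, so it bears on the present change only in that the piperidine of compound 2 is again replaced; 4-methylpiperazin-1-yl itself has no measured counterpart here. For compound 3 the expected step is a 3.0-fold higher number from compound 2 to compound 3 (0.47 log units; beyond the scatter), a move toward weaker binding that stays well short of the measured step. Compound 3 is therefore estimated at 700 nM, with a range from 150 nM to 4000 nM.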

Compound 3, half-maximal inhibitory concentration: 220 nM
Beside the measured number, compound 3's estimate is 3.2-fold (0.50 log units) above it, and the stated range covers the measured number.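

In this assay compound 2 and compound 3 do not separate (a 1.1-fold lower number from compound 2 to compound 3 (0.03 log units; within the scatter)), so at this position 4-methylpiperazin-1-yl, with no hydrogen-bond donor, reads alike with 4-hydroxy-4-methylpiperidin-1-yl, which carries one. The piperazine ring as such therefore does not go with the weak result of compound 1: with methyl in place of methylsulfonyl on the ring amine nitrogen, the series shows a large step (an at least 45-fold lower number from compound 1 to compound 3 (1.65 log units; beyond the scatter)). The value of compound 1 is a limit, so that step is a lower bound: the limit of > 10000 nM in this assay, at which 1 of the 3 values shown sits.

Open, on these data alone, is how other groups on that ring nitrogen, such as acetyl or a longer alkyl chain, would read against methyl and methylsulfonyl. Also open, as far as these compounds go, is whether a plain piperidine or a morpholine at this position would stay level with compound 2 and compound 3.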